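From Hydroxymethyl to Acetyl at a Central Chain Carbon

This account rests on a few compounds, and the source may have more. Where it says the series, first, only, none or still open, it means among the compounds named here.

The series is followed in a functional assay on cells (Hepatocyte, Rattus norvegicus, strain Sprague-Dawley) for inhibition; a lower number here means a stronger inhibitor, a higher number a weaker inhibitor. Compound 1 (`CC(C)(CO)CCCCC(O)CCCCC(C)(C)CO`) carries a hydroxy on a saturated chain carbon bound to two saturated chain carbons, and in this assay compound 1 gives 6400 nM. Compound 2 (`CC(C)(CO)CCCCC(CO)CCCCC(C)(C)CO`) carries a hydroxymethyl at that place instead, and in this assay compound 2 gives 15000 nM. For the measured compounds named here, the single measured step, a 2.3-fold higher number from compound 1 to compound 2 (0.37 log units; beyond the scatter), is the only guide available. Among the two numbers known, compound 2 stands highest, with compound 1 as its only neighbour.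

Compound 3 (`CC(=O)C(CCCCC(C)(C)CO)CCCCC(C)(C)CO`) differs from compound 2 in one place: acetyl in place of hydroxymethyl on a saturated chain carbon bound to two saturated chain carbons. Going by the values given here, the one measured step bears on it only loosely: it shows that hydroxymethyl in place of hydroxy at this position gave a modest rise, while the present exchange puts acetyl there and removes the hydrogen-bond donor. With a single modest step to go on, the expected change is small, a 1.3-fold higher number from compound 2 to compound 3 (0.12 log units; within the scatter), and may not exceed the scatter. Compound 3 is therefore expected to give about 20000 nM in this assay, within a range of 8000 nM to 50000 nM.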

Compound 3, half-maximal inhibitory concentration: 46000 nM
Compound 3: middle estimate off by 2.3-fold (0.36 log units), on the low side; measured number inside the range.
By their numbers in this assay, from the lowest: compound 1; then compound 2; then compound 3.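

In this assay, the saturated chain carbon bound to two saturated chain carbons responds a second time to a change of group: acetyl in place of hydroxymethyl gives a 3.1-fold higher number from compound 2 to compound 3 (0.49 log units; beyond the scatter). Set against the hydroxy group, the same acetyl gives a 7.2-fold higher number from compound 1 to compound 3 (0.86 log units; beyond the scatter), so all three compounds now stand apart beyond the scatter, with compound 1 the strongest inhibitor of the three and compound 3 the weakest. The exchange of hydroxymethyl for acetyl replaces a group with a hydrogen-bond donor by one with none, and it also adds a heavy atom and a double bond, so these differences arrive together in a single step and the three compounds cannot separate them.

Nothing measured here explains the rise in the number at this position. From the compounds shown here alone, it remains open how this carbon would respond to an amine, a carboxylic acid or a methoxy group, and whether a secondary alcohol bearing one more carbon, the closest relative of acetyl that keeps a hydrogen-bond donor, would stay nearer to compound 2 or to compound 3.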